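The source may report more compounds than this note shows. Statements on the series, on what has been measured and on what is new or still open speak of the compounds shown alone.

In an ADME assay on microsomes from liver (Mus musculus) for metabolic stability, read by LC-MS (on this read-out higher numbers stand for fast clearance and lower numbers for slow clearance), the measured compounds stand as follows:
Compound 1 `C[C@H]1CCCC[C@H]1NC(=O)c1cc2c(Cl)cc(Cl)cc2[nH]1` gives 89 mL.min-1.g-1
Compound 2 `C[C@H]1CCCC[C@H]1NC(=O)c1cc2c(F)cc(F)cc2[nH]1` gives 660 mL.min-1.g-1
Compound 3 `CC1CCC(NC(=O)c2cc3c(F)cc(F)cc3[nH]2)CC1` gives 866 mL.min-1.g-1

Compound 1 has the lowest number of the three, and its gaps to compound 2 and compound 3 both lie beyond the scatter. Compound 4 `C[C@H]1CC[C@@H](NC(=O)c2cc3c(Cl)cc(Cl)cc3[nH]2)CC1` keeps the core of compound 1 and changes one group. The change 4-methylcyclohexyl in place of 2-methylcyclohexyl on an amide-type nitrogen puts 4-methylcyclohexyl in place of 2-methylcyclohexyl on an amide-type nitrogen. The same swap has been measured once. Because of a 1.3-fold higher number from compound 2 to compound 3 (0.12 log units; within the scatter) no step beyond the scatter is expected in this assay for compound 4, although that single example sits on the core of compound 2 and not on the core of compound 1. The expected step is a 1.2-fold higher number from compound 1 to compound 4 (0.09 log units; within the scatter) and it stays within the scatter. Compound 4 is therefore expected near 110 mL.min-1.g-1 with an estimated range from 50 mL.min-1.g-1 to 250 mL.min-1.g-1 in this measurement.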

Compound 4, intrinsic clearance in microsomes: 47 mL.min-1.g-1
Estimate against measurement, compound 4: 2.3-fold (0.37 log units) above, and the stated range ends above it.
By their numbers in this assay, from the lowest: compounds 4 and 1 (each within the scatter of the next); then compounds 2 and 3 (each within the scatter of the next).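

In this assay, 4-methylcyclohexyl in place of 2-methylcyclohexyl on an amide-type nitrogen gives a 1.9-fold lower number from compound 1 to compound 4 (0.28 log units; within the scatter), so this swap can now be read on the core of compound 1 as well as on the core of compound 2. On both cores the step stays within the scatter, and these two pairs do not separate the two methylcyclohexyl groups. Nothing shown explains this result.

As far as these compounds go, it remains open whether a longer chain on that nitrogen, or an amine in place of the methyl on the cyclohexyl ring, would give a step beyond the scatter.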